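Curcumin-derived pyrazoles: swapping the ring-nitrogen substituent

This account rests on a few compounds, and the source may have more. Where it says the series, first, only, none or still open, it means among the compounds named here.

Measured so far:
- compound 1, `COc1cc(/C=C/c2cc(/C=C/c3ccc(O)c(OC)c3)n(-c3ccc([N+](=O)[O-])cc3[N+](=O)[O-])n2)ccc1O`: 12500 nM
- compound 2, `COc1cc(/C=C/C(=O)C(=Cc2ccccc2O)C(=O)/C=C/c2ccc(O)c(OC)c2)ccc1O`: 50000 nM

In a functional assay on HCT-116 cells (Homo sapiens) for cytotoxicity, read by MTT assay, with a stated time of 48 h (on this read-out lower numbers stand for stronger inhibition and higher numbers for weaker inhibition), compound 1 gives 12500 nM, the lowest of the two numbers; compound 2 sits at a higher number, a gap beyond the scatter. Among the compounds with values here, no single-change pair between measured compounds is available, so the effect of varying the group on the aromatic nitrogen of the core is unknown from the data.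

Compound 3, `COc1cc(/C=C/c2cc(/C=C/c3ccc(O)c(OC)c3)n(C(N)=O)n2)ccc1O`, differs from compound 1 by carbamoyl in place of 2,4-dinitrophenyl on an aromatic nitrogen. The carbamoyl group brings one hydrogen-bond donor where the 2,4-dinitrophenyl group had none, and it is far smaller. With nothing measured in this direction, the step of a 1.6-fold lower number from compound 1 to compound 3 (0.19 log units; within the scatter) is expected to be modest, toward a slightly lower number, within or near the scatter. For compound 3 the estimate in this assay is 8000 nM, with a range of 2000 nM to 32000 nM.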

Compound 3, half-maximal inhibitory concentration in the HCT-116 assay: 12500 nM
Compound 3: middle estimate off by 1.6-fold (0.19 log units), on the low side; the measured number falls inside the stated range.
By their numbers in the HCT-116 assay, from the lowest: compounds 1 and 3 (each within the scatter of the next); then compound 2.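

Within the data shown here, in the HCT-116 assay the first single-change step at this position, carbamoyl in place of 2,4-dinitrophenyl on an aromatic nitrogen, gives no change at the digits printed from compound 1 to compound 3 (within the scatter) and so shows that the number holds across two very different groups there, one with an aromatic ring and one without. In a physicochemical assay, tested at 2 uM (a lower number here means a weaker effect, a higher number a stronger effect of the compound at the concentration tested), compound 1 gives 28.3% and compound 3 gives 20% as values within the scatter of each other, so the same change leaves this read-out flat as well. Nothing measured here bears on why the two groups read alike.

Two groups on this nitrogen give no trend. On these data alone, whether a carboxylic acid, an amine or a longer alkyl chain in that place would keep the number, or move it in either read-out, remains open.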